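Swapping the Aryl Group on a Shared Hydrazone Core

The source may hold more compounds than are shown below. What is called first, only, known or untested is meant among the compounds shown, and "the series" means these compounds.

The two measured compounds share one core and differ only in the aryl group on a carbon with a double bond to nitrogen. Compound 1 `Cn1c(=O)c(=O)n(C2CCCC2)c2nc(N/N=C/c3ccc(S(C)(=O)=O)cc3)ncc21` carries 4-(methylsulfonyl)phenyl there, and in a functional assay on PC-3 cells (Homo sapiens) for antiproliferative activity, read by MTT assay (on this read-out higher numbers stand for weaker inhibition and lower numbers for stronger inhibition), compound 1 gives 26600 nM. Compound 2 `COc1ccc(/C=N/Nc2ncc3c(n2)n(C2CCCC2)c(=O)c(=O)n3C)c(OC)c1` carries 2,4-dimethoxyphenyl in its place. For compound 2 this assay reports only a limit, > 100000 nM. The single measured step, an at least 3.7-fold higher number from compound 1 to compound 2 (0.57 log units; beyond the scatter), therefore points toward weaker inhibition, and compound 2 stands at the weak end of the two numbers shown, resting at the limit described by the limit of > 100000 nM in this assay, at which 1 of the 2 values shown sits.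

Compound 3 `Cn1c(=O)c(=O)n(C2CCCC2)c2nc(N/N=C/c3cccc([N+](=O)[O-])c3)ncc21` changes this same group again: 3-nitrophenyl in place of 2,4-dimethoxyphenyl on a carbon with a double bond to nitrogen. Within the data shown here, only the step from compound 1 to compound 2 bears on this change, and it showed that exchanging the aryl group alone moved the number beyond the scatter. Compound 3 is expected to return to a measurable number, with the step of an at least 2.5-fold lower number from compound 2 to compound 3 (0.39 log units; beyond the scatter) estimated to lower the number in this assay. Compound 3 is estimated at 40000 nM, within a range from 12000 nM to 130000 nM.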

Compound 3, half-maximal inhibitory concentration: 20300 nM
The estimate for compound 3 lay 2.0-fold (0.29 log units) above the measured number; measured number inside the range.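

In this assay, the third aryl group shows that the loss seen with 2,4-dimethoxyphenyl does not extend to every replacement on this carbon with a double bond to nitrogen: the change to 3-nitrophenyl gives an at least 4.9-fold lower number from compound 2 to compound 3 (0.69 log units; beyond the scatter), a shift beyond the scatter that brings the reading back to a measurable number. The other new comparison, a 1.3-fold lower number from compound 1 to compound 3 (0.12 log units; within the scatter), lies within the scatter, so 3-nitrophenyl and 4-(methylsulfonyl)phenyl cannot be told apart in this read-out, although they are different groups, and the two aryl groups now give a shared level against which compound 2 stands apart. The reading for compound 2 remains a limit of the assay and not a number, so the true size of its step stays unknown: the limit of > 100000 nM in this assay, at which 1 of the 3 values shown sits.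

The compounds shown leave open whether any aryl group at this place can move the number clearly past the level of compound 1 and compound 3. They also leave open what a phenyl ring bearing an amine, a carboxylic acid or a single methoxy group would give here, and so which feature of 2,4-dimethoxyphenyl goes with the weak reading.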